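This account rests on a few compounds, and the source may have more. Where it says the series, first, only, none or still open, it means among the compounds named here.

The measured compounds:

Compound 1, `C/C1=C/C2=C(CC(C)(C)C2=O)[C@H](C)CC[C@@H]1O`, in a functional assay on BGC-823 cells (Homo sapiens) for cytotoxicity, read by MTT assay (a higher number here means a weaker inhibitor, a lower number a stronger inhibitor), compound 1 gives > 10 ug/mL, a limit of the assay.
Compound 2, `C/C1=C/[C@]23O[C@]2(CC(C)(C)C3=O)[C@H](C)CC[C@@H]1O`, in this assay compound 2 gives > 10 ug/mL, again a limit.
Compound 3, `CC(=O)CC/C=C(/C)CC1=CC(C)(C)CC1=O`, in this assay compound 3 gives > 10 ug/mL, also a limit.

Compound 3 stands at the limit rather than at a number, and it shares that position with every other compound measured here: the limit of > 10 ug/mL in this assay, at which 3 of the 3 values shown sit. Among the measured compounds shown here, no step between two measured compounds can therefore be read, and nothing in the data sets any of the three apart from the others.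

Compound 4, `C/C(=C/CC[C@H](C)O)CC1=CC(C)(C)CC1=O`, has not yet been measured in this assay. It differs from compound 3 in one place: 1-hydroxyethyl in place of acetyl on a saturated chain carbon, two bonds along the chain from a double-bonded chain carbon. For the measured compounds named here, with compound 3 at the limit and no measured step to lean on, the change from compound 3 to compound 4 is expected to bring no shift beyond the scatter, and most likely compound 4 will also be reported only as a limit; the step that the limit leaves unreadable from compound 3 to compound 4 is the estimate meant here. Compound 4 is thus expected to give about 20 ug/mL in this assay, within a range from 8 ug/mL to 60 ug/mL.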

Compound 4, half-maximal inhibitory concentration: > 10 ug/mL
Compound 4 gave a limit, no number (the forecaster's own chance of this, stated with the estimate: 80%); the middle value is on the limit's open side.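

No step can be read between compound 3 and compound 4, since both stand at a limit in this assay: the limit of > 10 ug/mL in this assay, at which 4 of the 4 values shown sit.

The compounds shown leave open how the swap of acetyl for 1-hydroxyethyl affects potency, and whether any of the four has a measurable potency in this assay.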